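The source may hold more compounds than are shown below. What is called first, only, known or untested is meant among the compounds shown, and "the series" means these compounds.

Compound 1 `O=C(O)CCCCC(CCSC(=O)c1ccccc1)SC(=O)c1ccccc1`: 1.09%
Compound 2 `O=C(CCCCC1CCSS1)Nc1ccc([N+](=O)[O-])c(C(F)(F)F)c1`: 5.04%
Compound 3 `O=C(CCCCC(S)CCS)Nc1cccc(C(F)(F)F)c1`: 2.85%

These values come from a functional assay on Bel-7402 cells (Homo sapiens) for inhibition, read by MTT assay, with a stated time of 24 h, tested at 0.1 ug/mL; on this read-out lower numbers stand for less inhibition of growth and higher numbers for more inhibition of growth at the one concentration tested. Compound 1 stands within the usual scatter of both other compounds, so the three cannot be ranked. Compound 4 `O=C(CCCCC(CCSC(=O)c1ccccc1)SC(=O)c1ccccc1)Nc1cccc(Cl)c1` keeps the core of compound 1 but carries (3-chlorophenyl)amino in place of hydroxy on a carbonyl carbon. For the measured compounds named here, no measured pair shows this change alone. Compound 2 and compound 3 are also amides bearing an aromatic ring, yet neither stands apart from compound 1 at 1.09%. No step beyond the scatter is therefore expected in this assay. The estimated step is a number 3.9 percentage points higher from compound 1 to compound 4 (within the scatter). For compound 4 the estimated value is 5%, with an expected range of 0% to 16%.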

Compound 4, percent growth inhibition at one concentration: 1.7%
The estimate for compound 4 lay 3.3 percentage points above the measured number; the range from low to high includes it.
By their numbers in this assay, from the lowest: compounds 1, 4, 3 and 2 (each within the scatter of the next).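

For the compounds shown here, compound 1 and compound 4 are the first pair to differ in one place alone, so (3-chlorophenyl)amino in place of hydroxy on a carbonyl carbon can now be read directly. In this assay the change gives a number 0.6 percentage points higher from compound 1 to compound 4 (within the scatter). On this read-out, at the one concentration tested, the two compounds cannot be told apart, and nothing available explains this result.

Going by these compounds, whether a morpholine amide or a methyl ester at this carbonyl carbon would stand apart from compound 1 remains open.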